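Working notes: from butyl to isopropyl on the shared core

This account rests on a few compounds, and the source may have more. Where it says the series, first, only, none or still open, it means among the compounds named here.

Compound 1 `CCCCc1ccc2[nH]cc(C(=O)OC)c(=O)c2c1`: > 20000 nM (a limit)
Compound 2 `COC(=O)c1c[nH]c2cc(OCCCc3ccccc3)ccc2c1=O`: 1480 nM

In an ADME assay on J774 cells (Mus musculus) for cytotoxicity (on this read-out lower numbers stand for an effect already at smaller amounts and higher numbers for an effect only at larger amounts of compound), compound 1 gives > 20000 nM as a limit of the assay and not a number. Compound 3 `COC(=O)c1c[nH]c2ccc(C(C)C)cc2c1=O` differs from compound 1 by isopropyl in place of butyl on an aromatic carbon with isopropyl in place of butyl on an aromatic carbon. Among the compounds with values here, no measured step speaks to this change. In this assay the expected step that the limit leaves unreadable from compound 1 to compound 3 is none beyond the scatter, in either direction. For compound 3 the estimate is 22000 nM with an expected range (9000 nM to 50000 nM).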

Compound 3, half-maximal effective concentration: > 20000 nM
Compound 3: only a limit was reported; the forecaster's own chance of this, stated with the estimate: 70%; the middle value does not contradict the limit.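

No step can be read from compound 1 to compound 3 in this assay, since both results are limits and not numbers: the limit of > 20000 nM in this assay, at which 2 of the 3 values shown sit.

The compounds shown leave open whether isopropyl and butyl on an aromatic carbon differ at all on this read-out.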